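The source may hold more compounds than are shown below. What is called first, only, known or untested is meant among the compounds shown, and "the series" means these compounds.

Compound 1 `Cc1nn(C)c2c1C(c1ccccc1)=NCC(=O)N2` is the smallest of the three compounds measured. In a functional assay on the whole organism with Rattus norvegicus as the target (a higher number here means that more compound is needed for the effect, a lower number that less compound is needed), compound 1 gives 16 mg/kg. Compound 2 `CCc1nn(C)c2c1C(c1ccccc1)=NCC(=O)N2` differs from compound 1 by methyl in place of hydrogen on a saturated chain carbon bound to an aromatic carbon and in this assay compound 2 gives 8 mg/kg, a step of a 2.0-fold lower number from compound 1 to compound 2 (0.30 log units; within the scatter). Compound 3 `CCc1nn(C)c2c1C(c1ccccc1Cl)=NCC(=O)N2` carries a chloro substituent that compound 2 lacks, and in this assay compound 3 gives 32 mg/kg, so the chloro step reads a 4.0-fold higher number from compound 2 to compound 3 (0.60 log units; beyond the scatter). Between compound 1 and compound 3 the difference is not broken down here; their two values lie within the usual scatter of each other.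

Compound 4 `CC(C)c1nn(C)c2c1C(c1ccccc1Cl)=NCC(=O)N2` has not yet been measured. It differs from compound 3 by methyl in place of hydrogen on a saturated chain carbon bound to an aromatic carbon and a saturated chain carbon. For the measured compounds named here, this is the same kind of change as the one separating compound 1 and compound 2, but not the same place: there the carbon receiving the methyl is bound to an aromatic carbon only, whereas here it is bound to an aromatic carbon and a saturated chain carbon. Going by the values given here, the one earlier example of this kind of change gave a 2.0-fold lower number from compound 1 to compound 2 (0.30 log units; within the scatter), which lies within the scatter, so a comparable, small step is expected.

For compound 4 the expected step is a 1.3-fold lower number from compound 3 to compound 4 (0.12 log units; within the scatter), because the earlier example gave a 2.0-fold lower number from compound 1 to compound 2 (0.30 log units; within the scatter) and nothing here points to a larger effect. For compound 4 in this assay the estimate is 24 mg/kg, with a likely range from 8 mg/kg to 64 mg/kg.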

Compound 4, minimum effective dose: 125 mg/kg
Estimate against measurement, compound 4: 5.2-fold (0.72 log units) below, outside the stated range (above it).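

On the chloro-bearing core, the extra methyl that turns ethyl into isopropyl gives a 3.9-fold higher number from compound 3 to compound 4 (0.59 log units; beyond the scatter), so more compound is needed for the effect, and the same kind of change does not carry over as one fixed step from one core to the other in this assay: the same change on two cores in this assay, a 2.0-fold lower number (0.30 log units; within the scatter) from compound 1 to compound 2 and a 3.9-fold higher number (0.59 log units; beyond the scatter) from compound 3 to compound 4, 7.8-fold (0.89 log units) apart, beyond the scatter of two such steps

What this does not show is which difference between the two cases matters. The cases differ in two ways at once: compound 3 carries a chloro substituent that compound 1 lacks, and the methyl lands on a saturated chain carbon bound to an aromatic carbon and a saturated chain carbon rather than on a carbon bound to an aromatic carbon only. With a single example of each, the comparison gives no general rule for this series and no explanation for the gap.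

An isopropyl group on the core without chloro would separate these two differences, and that pairing is absent from the compounds shown. Also open, on these data alone, is how a longer chain such as propyl, or a chain ending in an amine, would read in this assay, and whether a fluoro group in place of chloro would give a step like the chloro step.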